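This account rests on a few compounds, and the source may have more. Where it says the series, first, only, none or still open, it means among the compounds named here.

In a functional assay on HL-60 cells (Homo sapiens) for antiproliferative activity, read by MTT assay, with a stated time of 72 h (a lower number here means a stronger inhibitor, a higher number a weaker inhibitor), compound 1 `NC1=NC2(CCOCC2)N(OCCCOc2ccc(Cl)cc2)C(N)=N1` gives 330 nM and compound 2 `NC1=NC2(CCOCC2)N(OCCCOc2cc(Cl)c(Cl)cc2Cl)C(N)=N1` gives 2360 nM, so compound 1 holds the lower, stronger of the two numbers. Compound 3 `CC(C)(C)c1ccc(OCCCON2C(N)=NC(N)=NC23CCOCC3)cc1` keeps the rest of compound 1 and differs in one place: tert-butyl in place of chloro on an aromatic carbon. For the measured compounds named here, the one measured step that bears on this is a 7.2-fold higher number from compound 1 to compound 2 (0.85 log units; beyond the scatter), with 2,4,5-trichlorophenyl in place of 4-chlorophenyl. That is a different change, so it offers only a loose guide, but it does show a modest loss in this assay when this part of compound 1 is altered. A modest move to a higher number is therefore expected, though a result within the scatter remains possible. The expected step is a 2.1-fold higher number from compound 1 to compound 3 (0.33 log units; beyond the scatter). For compound 3 the estimate is 700 nM, with an expected range of 180 nM to 3000 nM.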

Compound 3, half-maximal inhibitory concentration: 870 nM
Estimate against measurement, compound 3: 1.2-fold (0.09 log units) below; low and high end bracket the measured number.
By their numbers in this assay, from the lowest: compound 1; then compound 3; then compound 2.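

In this assay the swap of chloro for tert-butyl, on an aromatic carbon para to a large group, gives a 2.6-fold higher number from compound 1 to compound 3 (0.42 log units; beyond the scatter) and leaves compound 1 with the lowest of the three numbers. Compound 2 kept a chlorine at this place and gained others, so it could not show what happens when this chloro itself leaves; in compound 3 four carbon heavy atoms replace one chlorine, with no hydrogen-bond donor or acceptor in either group. Nothing measured here explains the rise in the number.

Still open, on these data alone, is whether fluoro, methoxy, an amine or a carboxylic acid at this place would keep the number near that of compound 1 or lower it. Also open, as far as these compounds go, is how a longer chain carrying the same aromatic ring would behave.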